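Thiophene for methylthiazole at the aryl ether linker

The compounds below may be only part of what the source reports. "The series", "measured", "known", "first", "only" and "open" are said of these compounds alone.

Of the compounds shown here, two have been measured so far. Compound 1 `O=C1N=C(O)S/C1=C\c1ccc(OCCc2ccccn2)cc1` gives 660 nM in an assay for inhibition of 15-hydroxyprostaglandin dehydrogenase [NAD(+)] (Homo sapiens), read by fluorescence and spectrophotometry; on this read-out lower numbers stand for stronger inhibition and higher numbers for weaker inhibition. Compound 2 `Cc1ncsc1CCOc1ccc(/C=C2\SC(O)=NC2=O)cc1` gives 636 nM in this assay. Compound 2 stands level with compound 1 on these numbers: the step of a 1.0-fold lower number from compound 1 to compound 2 (0.02 log units; within the scatter) is within the scatter, so the exchange of the aromatic ring at the end of the two-carbon chain left the read-out unchanged.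

Compound 3 `O=C1N=C(O)S/C1=C\c1ccc(OCc2ccsc2)cc1` is the next candidate. It differs from compound 2 by thiophen-3-yl in place of (4-methyl-1,3-thiazol-5-yl)methyl on a saturated chain carbon bound to an oxygen on an aromatic ring; the aromatic ring at the end of the linker is again exchanged, and the linker to the oxygen on the aromatic ring becomes shorter. Among the measured compounds shown here, only the step from compound 1 to compound 2 bears on this, and it showed no movement beyond the scatter for a heteroaryl swap at that end of the molecule. For the measured compounds named here, for the shortening of the linker no measured step exists. On this basis no step beyond the scatter is expected in this assay, with a widened range to cover the untested linker change. Compound 3 is therefore expected to give 700 nM, range 250 nM to 2000 nM, corresponding to an expected step of a 1.1-fold higher number from compound 2 to compound 3 (0.04 log units; within the scatter).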

Compound 3, half-maximal inhibitory concentration: 429 nM
Compound 3: the middle estimate sits 1.6-fold (0.21 log units) above what was measured; measured number inside the range.
By their numbers in this assay, from the lowest: compounds 3, 2 and 1 (each within the scatter of the next).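

In this assay, thiophen-3-yl in place of (4-methyl-1,3-thiazol-5-yl)methyl on a saturated chain carbon bound to an oxygen on an aromatic ring gives a 1.5-fold lower number from compound 2 to compound 3 (0.17 log units; within the scatter), and thiophen-3-yl in place of (pyridin-2-yl)methyl at the same place gives a 1.5-fold lower number from compound 1 to compound 3 (0.19 log units; within the scatter). Where the earlier pair showed only that one end ring could replace another on a linker of unchanged length, these steps show the read-out staying level when the end ring and the linker length change together, and with a ring that has no nitrogen, so a ring nitrogen, present in both compound 1 and compound 2, is not needed for a read-out at this level. Nothing on hand explains this level read-out.

The compounds shown leave open what the ring exchange and the shorter linker each contribute alone, since the two change together in both steps, and a thiophen-3-yl on the longer linker of compound 2 would separate them. They also leave open whether this end of the molecule stays as level with an amine or a carboxylic acid on the end ring, or with a longer chain.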